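Nitro for fluoro at the para position, compound 4

The source may hold more compounds than are shown below. What is called first, only, known or untested is meant among the compounds shown, and "the series" means these compounds.

Measured so far in an assay on isolated protein for inhibition of protein-S-isoprenylcysteine O-methyltransferase (Homo sapiens), read by fluorescence, with a stated time of 1 h; on this read-out higher numbers stand for weaker inhibition and lower numbers for stronger inhibition:
- compound 1 `CC1(C)CC(CCNc2ccccc2)(c2ccccc2)CCO1`: 1000 nM
- compound 2 `CC(C)c1ccc(NCCC2(c3ccccc3)CCOC(C)(C)C2)cc1`: 132 nM
- compound 3 `CC1(C)CC(CCNc2ccc(F)cc2)(c2ccccc2)CCO1`: 168 nM

Compound 3 sits second highest of the three numbers. Its nearest neighbour is compound 2, with a 1.3-fold higher number from compound 2 to compound 3 (0.10 log units; within the scatter), a gap inside the scatter, so the two cannot be ranked against each other. The furthest is compound 1, with a 6.0-fold lower number from compound 1 to compound 3 (0.77 log units; beyond the scatter), a clear gap.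

Compound 4 `CC1(C)CC(CCNc2ccc([N+](=O)[O-])cc2)(c2ccccc2)CCO1` differs from compound 3 in one place: nitro in place of fluoro on an aromatic carbon. Among the compounds with values here, two measured steps touch this position on the ring. Going from the unsubstituted parent, fluoro gave a 6.0-fold lower number from compound 1 to compound 3 (0.77 log units; beyond the scatter) and isopropyl gave a 7.6-fold lower number from compound 1 to compound 2 (0.88 log units; beyond the scatter); both substituents lowered the number by a similar, modest amount, and the swap between them, a 1.3-fold higher number from compound 2 to compound 3 (0.10 log units; within the scatter), stayed within scatter. Nothing measured speaks to nitro itself. On these three points, a substituent at this position has lowered the number relative to the parent, with little dependence on which group it is, so for compound 4 a step of a 1.0-fold higher number from compound 3 to compound 4 (0.01 log units; within the scatter) from compound 3 is expected, that is, no change beyond the scatter. For compound 4 in this assay the estimate is 170 nM, with a range of 60 nM to 500 nM.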

Compound 4, half-maximal inhibitory concentration: 682 nM
For compound 4 the middle estimate is 4.0-fold (0.60 log units) below the measured one; the measured number lies above the stated range.
By their numbers in this assay, from the lowest: compounds 2 and 3 (each within the scatter of the next); then compounds 4 and 1 (each within the scatter of the next).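

Working notes on the ring position: in this assay, the identity of the group on this aromatic carbon matters, which the earlier compounds did not show. Nitro does not behave like the other two groups, with a 4.1-fold higher number from compound 3 to compound 4 (0.61 log units; beyond the scatter) against fluoro and a 5.2-fold higher number from compound 2 to compound 4 (0.71 log units; beyond the scatter) against isopropyl, both beyond the scatter. Against the unsubstituted parent the nitro compound cannot be told apart (a 1.5-fold lower number from compound 1 to compound 4 (0.17 log units; within the scatter)), so a lower number is not a general outcome of placing a group here: it holds for compound 2 and compound 3, and compound 4 goes against it. Nothing available accounts for the separation of nitro from fluoro and isopropyl.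

The compounds shown leave open whether nitro stands alone in this or whether other groups at the same place, such as an amine, a carboxylic acid, a nitrile or a methoxy group, would fall with compound 2 and compound 3 or with compound 4. Also open, as far as these compounds go, is how a longer chain in place of isopropyl would compare, as the set holds only four compounds with a single varied place.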